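The source may hold more compounds than are shown below. What is called first, only, known or untested is meant among the compounds shown, and "the series" means these compounds.

Compound 1, with the structure `COc1cc(C(=O)N2CCN(C(=O)c3cc(OC)c(OC)c(OC)c3)C(COC(=O)C3CCCCC3)C2)cc(OC)c1OC`, stands lowest of the two numbers gathered so far. In a functional assay (Oryctolagus cuniculus) for inhibition of platelet-activating factor receptor (Cavia porcellus) (on this read-out lower numbers stand for stronger inhibition and higher numbers for weaker inhibition), compound 1 gives 290 nM. Going by the values given here, the only other measured compound, compound 2, `CCC(CC)C(=O)OCC1CN(Cc2cc(OC)c(OC)c(OC)c2)CCN1Cc1cc(OC)c(OC)c(OC)c1`, differs from it in more than one place; in this assay compound 2 gives 2700 nM, a higher number that lies beyond the scatter. Compound 3, `CCCN(CCC)C(=O)OCC1CN(C(=O)c2cc(OC)c(OC)c(OC)c2)CCN1C(=O)c1cc(OC)c(OC)c(OC)c1`, keeps the shared core of compound 1 and changes only the group on a carbonyl carbon whose other neighbours are oxygen next to a carbonyl group: dipropylamino in place of cyclohexyl on a carbonyl carbon. Among the compounds with values here, no pair of measured compounds isolates this change, so nothing measured tells how dipropylamino in place of cyclohexyl moves the read-out. The step of a 1.2-fold higher number from compound 1 to compound 3 (0.08 log units; within the scatter) is therefore expected to be small, not clearly beyond the scatter in either direction. For compound 3 the expected value in this assay is 350 nM, in a range from 100 nM to 1200 nM.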

Compound 3, half-maximal inhibitory concentration: 380 nM
Compound 3: middle estimate off by 1.1-fold (0.04 log units), on the low side, within the range that was stated.
By their numbers in this assay, from the lowest: compounds 1 and 3 (each within the scatter of the next); then compound 2.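

In this assay, going by these compounds alone, the exchange on a carbonyl carbon whose other neighbours are oxygen next to a carbonyl group gives a 1.3-fold higher number from compound 1 to compound 3 (0.12 log units; within the scatter) and thereby isolates this change for the first time. For this pair, the read-out stays within the scatter when cyclohexyl, a six-membered ring of carbon only, leaves and dipropylamino, with no ring and one nitrogen, enters, so the ring is not needed to keep the read-out of compound 1 on this core. Nothing measured here accounts for this outcome.

The compounds shown leave open whether a shorter group such as dimethylamino, or a ring amine such as piperidin-1-yl, would also stay within the scatter at this position. They also leave open how a longer chain such as dihexylamino would read, or a carboxylic acid carried on the same carbonyl carbon's chain.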